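Swapping a hydrogen for chloro on the phenyl ring

This account rests on a few compounds, and the source may have more. Where it says the series, first, only, none or still open, it means among the compounds named here.

Of the compounds shown here, two from this series have been tested so far. Compound 1 `CCOC(=O)c1c(-c2c(Cl)c3cc(C)ccc3oc2=O)nn(-c2cccc(C)c2)c1C(=O)OCC` gives, in a functional assay on A549 cells (Homo sapiens) for cytotoxicity, read by MTT assay, with a stated time of 48 h (on this read-out higher numbers stand for weaker inhibition and lower numbers for stronger inhibition), a value of 115000 nM. Compound 2 `CCOC(=O)c1c(-c2cc3ccccc3oc2=O)nn(-c2ccccc2)c1C(=O)OCC` gives in this assay a value of 100000 nM. The two numbers lie within the scatter of each other, so neither can be called stronger, and both indicate only weak cytotoxicity in this setting.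

Compound 3 `CCOC(=O)c1c(-c2cc3ccccc3oc2=O)nn(-c2cccc(Cl)c2)c1C(=O)OCC` has not yet been measured. It differs from compound 2 by chloro in place of hydrogen on an aromatic carbon, so that a phenyl becomes a 3-chlorophenyl. Among the compounds with values here, no pair of measured compounds shows such a change, so its effect here is unknown. Adding one chlorine atom to a ring that bears no other substituent is a small change, and a step no larger than the scatter, in either direction, is expected. The expected step is a 1.1-fold lower number from compound 2 to compound 3 (0.05 log units; within the scatter). Compound 3 is therefore estimated at 90000 nM, with a range from 40000 nM to 200000 nM.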

Compound 3, half-maximal inhibitory concentration: 28000 nM
The estimate for compound 3 lay 3.2-fold (0.51 log units) above the measured number; measured number below the stated range.
By their numbers in this assay, from the lowest: compound 3; then compounds 2 and 1 (each within the scatter of the next).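

This position on the phenyl ring does respond to a change: in this assay, chloro in place of hydrogen on this aromatic carbon, meta to a large group, gives a 3.6-fold lower number from compound 2 to compound 3 (0.55 log units; beyond the scatter), which means stronger inhibition, though the step is only modest. Within the data shown here, this is the first measured pair that differs in one place, so the effect of a single ring substituent can now be read on its own. Nothing measured here explains why one chlorine atom shifts the number in this way.

On these data alone, only hydrogen and chloro have been compared at this carbon, so it remains open whether a methoxy group, an amine or a carboxylic acid there would lower the number further, leave it unchanged or raise it. Also open, as far as these compounds go, is whether chloro would give a similar step on another carbon of the phenyl ring.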